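The source may report more compounds than this note shows. Statements on the series, on what has been measured and on what is new or still open speak of the compounds shown alone.

Of the compounds shown here, three built on one shared core have been tested in a functional assay on HL-60 cells (Homo sapiens) for antiproliferative activity, read by MTT assay, with a stated time of 48 h; on this read-out higher numbers stand for weaker inhibition and lower numbers for stronger inhibition. Compound 1 `CCn1c(N)c(-c2nc3ccccc3[nH]2)c2nc(C#N)c(C#N)nc21`, with an ethyl chain, gives > 50000 nM, which is a limit and not a number. Compound 3 `CCCCn1c(N)c(-c2nc3ccccc3[nH]2)c2nc(C#N)c(C#N)nc21`, with a butyl chain, gives > 50000 nM, which is also a limit. Compound 3 therefore stands at the limit of > 50000 nM in this assay, at which 2 of the 3 values shown sit. Compound 2 `N#Cc1nc2c(-c3nc4ccccc4[nH]3)c(N)n(CCN3CCCC3)c2nc1C#N`, whose chain ends in pyrrolidin-1-yl, gives a true number of 4760 nM. Adding that group produces an at least 10-fold lower number from compound 1 to compound 2 (1.02 log units; beyond the scatter), and exchanging it for ethyl produces an at least 10-fold higher number from compound 2 to compound 3 (1.02 log units; beyond the scatter). Lengthening the chain alone gives a step that the two limits leave unreadable from compound 1 to compound 3.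

Compound 4 `N#Cc1nc2c(-c3nc4ccccc4[nH]3)c(N)n(CCCN3CCCCC3)c2nc1C#N` differs from compound 3 by piperidin-1-yl in place of methyl on a saturated chain carbon, three bonds along the chain from an aromatic nitrogen: piperidin-1-yl in place of methyl, on a saturated chain carbon, three bonds along the chain from an aromatic nitrogen. Its chain also ends in a non-aromatic ring, as in compound 2, so a large step towards a lower number is expected in this assay. The estimated step is an at least 10-fold lower number from compound 3 to compound 4 (1.00 log units; beyond the scatter). Within the data shown here, no measured compound tests this chain length or ring size, so the range is kept wide. For compound 4 the expected value is 5000 nM, within an estimated range of 1500 nM to 20000 nM.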

Compound 4, half-maximal inhibitory concentration: 1680 nM
Beside the measured number, compound 4's estimate is 3.0-fold (0.47 log units) above it, and the stated range covers the measured number.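

Chains ending in a non-aromatic ring now give a true number twice, so this gain in this assay is not confined to compound 2: piperidin-1-yl gives an at least 29-fold lower number from compound 3 to compound 4 (1.47 log units; beyond the scatter) and an at least 29-fold lower number from compound 1 to compound 4 (1.47 log units; beyond the scatter). Among the ring-ending chains, the comparison gives a 2.8-fold lower number from compound 2 to compound 4 (0.45 log units; beyond the scatter), a modest step in which ring size and chain length change together, so neither can be credited alone. Compound 1 and compound 3, whose chains carry no ring, each remain at a limit and not a number: the limit of > 50000 nM in this assay, at which 2 of the 4 values shown sit.

What the chain-end ring contributes, as distinct from its nitrogen, stays open, since no open-chain amine such as dimethylamino is shown at that position. Also open, from the compounds shown here alone, is how a morpholine ring would compare on the same chain.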